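Removing chloro and nitro from a diaryl urea

A few compounds are considered here, and "the series" means these few. Any claim that something is new, unique, unknown or untested is made for them only; others in the source may bear on it.

Compound 3 `O=C(Nc1ccc(Oc2ccc(-c3ncc[nH]3)cc2)cc1)Nc1ccc(Cl)c([N+](=O)[O-])c1`, tested in a functional assay on A549 cells (Homo sapiens) for inhibition, read by MTT assay and WST assay, with a stated time of 72 h, tested at 10 uM (on this read-out higher numbers stand for more inhibition of growth at the one concentration tested and lower numbers for less inhibition of growth), gives 12.4%. This puts it second highest among three numbers: compound 1 `Cc1ccc(NC(=O)Nc2ccc(Oc3ccc(-c4nccs4)cc3)cc2)cc1` gives 15.6% and compound 2 `O=C(Nc1ccc(Cl)cc1)Nc1ccc(Oc2ccc(-c3ncc[nH]3)cc2)cc1` gives 8.86%, both within the scatter of compound 3. Compound 4 `Cc1ccc(NC(=O)Nc2ccc(Oc3ccc(-c4ncc[nH]4)cc3)cc2)cc1` differs from compound 3 by 4-methylphenyl in place of 4-chloro-3-nitrophenyl on an amide-type nitrogen. Among the compounds with values here, the only measured step that touches this part of the molecule is a number 3.5 percentage points higher from compound 2 to compound 3 (within the scatter), which was within the scatter. Compound 1 already carries 4-methylphenyl on the urea, with a different five-membered ring elsewhere, and its value sits close to compound 3. Compound 4 is therefore expected to show a number 0.4 percentage points lower from compound 3 to compound 4 (within the scatter), no movement beyond the scatter, with an estimated 12% in a range from 3% to 22%.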

Compound 4, percent growth inhibition at one concentration: 24.6%
Beside the measured number, compound 4's estimate is 12.6 percentage points below it; measured number outside the range, above it.
By their numbers in this assay, from the lowest: compounds 2, 3, 1 and 4 (each within the scatter of the next, the first and the last beyond it).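

In this assay, within the data shown here, 4-methylphenyl in place of 4-chloro-3-nitrophenyl on an amide-type nitrogen gives a number 12.2 percentage points higher from compound 3 to compound 4 (beyond the scatter) and is the first step at this position to pass the scatter. Among these compounds, with no nitro on either compound, methyl in place of chloro on an aromatic carbon gives a number 15.7 percentage points higher from compound 2 to compound 4 (beyond the scatter), so that single exchange is enough for a step of this kind. On the other side of the molecule, 1H-imidazol-2-yl in place of 1,3-thiazol-2-yl gives a number 9 percentage points higher from compound 1 to compound 4 (within the scatter) and separates nothing.

From the compounds shown here alone, whether an amine or a methoxy group in place of methyl would keep this level remains open. The data offer no explanation for these steps.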